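This account rests on a few compounds, and the source may have more. Where it says the series, first, only, none or still open, it means among the compounds named here.

Compounds measured so far:

compound 1, `COc1ccc(C2CC(c3cc(Cl)c(C)cc3O)=NN2c2ccc(S(N)(=O)=O)cc2)cc1OC`, with 68.3%
compound 2, `COc1ccc(C2CC(c3cc(Cl)c(C)cc3O)=NN2c2ccc(S(N)(=O)=O)cc2)c(OC)c1OC`, with 88.1%
compound 3, `COc1ccc(C2CC(c3cc(Cl)c(C)cc3OC)=NN2c2ccc(S(N)(=O)=O)cc2)cc1OC`, with 47.6%

All three were tested in a functional assay on the whole organism (strain Wistar) for inhibition, with Rattus norvegicus as the target, read by paw edema, with stated times of 30 min and 5 h, at a dose of 20 mg/kg by the oral route; on this read-out higher numbers stand for more inhibition at the one dose given (going by the name of the read-out) and lower numbers for less inhibition. Within this set, compound 2 gives the highest number and compound 3 the lowest, and each step between the three lies beyond the usual scatter. The first step, a number 19.8 percentage points higher from compound 1 to compound 2 (beyond the scatter), is a single change: methoxy in place of hydrogen on an aromatic carbon. The second step, a number 20.7 percentage points lower from compound 1 to compound 3 (beyond the scatter), also rests on one change, (methyl in place of hydrogen on an oxygen on an aromatic ring), which is also the only difference between the core of compound 3 and the core of compound 1.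

Compound 4, `COc1cc(C)c(Cl)cc1C1=NN(c2ccc(S(N)(=O)=O)cc2)C(c2ccc(OC)c(OC)c2OC)C1`, has not yet been measured in this assay . It differs from compound 3 in one place: methoxy in place of hydrogen on an aromatic carbon. The surroundings of that place are the same, word for word, as in the change that separates compound 2 from compound 1, so this is the same change made on the other core.

Since that change gave the step of a number 19.8 percentage points higher from compound 1 to compound 2 (beyond the scatter), the step in this assay from compound 3 to compound 4 is expected to be of similar direction and size, a number 17.4 percentage points higher from compound 3 to compound 4 (beyond the scatter), although a single earlier example carries a wide uncertainty. On that basis compound 4 is expected to give about 65% in this assay , with a plausible range from 50% to 80%.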

Compound 4, a percentage reported as inhibition, in the whole organism at one dose (the size of the read-out at that dose, not a potency): 21.4%
Estimate against measurement, compound 4: 43.6 percentage points above, and the stated range ends above it.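

Carried onto the other core in this assay, the change from 3,4-dimethoxyphenyl to 2,3,4-trimethoxyphenyl gave a number 26.2 percentage points lower from compound 3 to compound 4 (beyond the scatter), which runs in the opposite direction to the earlier step, so this change did not transfer between the two cores: the same change on two cores in this assay, a number 19.8 percentage points higher (beyond the scatter) from compound 1 to compound 2 and a number 26.2 percentage points lower (beyond the scatter) from compound 3 to compound 4, 46 percentage points apart, beyond the scatter of two such steps Read the other way, methyl in place of hydrogen on the oxygen lowered the number on both cores, but with the 2,3,4-trimethoxyphenyl group in place the step was much larger, a number 66.7 percentage points lower from compound 2 to compound 4 (beyond the scatter), so the two changes do not act independently of each other in these four compounds: the same change on two cores in this assay, a number 20.7 percentage points lower (beyond the scatter) from compound 1 to compound 3 and a number 66.7 percentage points lower (beyond the scatter) from compound 2 to compound 4, 46 percentage points apart, beyond the scatter of two such steps This shows that the outcome of each change depends on the other within this set, but it does not show why, and with only a single pair of steps for each change, read at one dose in the whole animal, it gives no general rule for the series.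

The compounds shown leave open how the methoxy change would behave with an ethyl group or a longer chain on that oxygen in place of methyl. They also leave open whether an amine or a carboxylic acid at the position of the added methoxy would follow either core's direction.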